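From 2-methylpyridin-4-yl to pyridin-4-yl: notes on compound 1

The source may hold more compounds than are shown below. What is called first, only, known or untested is meant among the compounds shown, and "the series" means these compounds.

The series is read in a functional assay on MCF7 cells (Homo sapiens) for cytotoxicity, with a stated time of 72 h; a higher number here means a weaker inhibitor, a lower number a stronger inhibitor. Compound 1 `Cc1cc(-c2c(-c3cccc(C)n3)nn3c2C(C)C(C)(C)C3)ccn1` gives > 100000 nM, which is a limit of the assay and not a number. Compound 3 `CC1(C)Cc2c(-c3ccncc3)c(-c3ccccn3)nn2C1` gives > 100000 nM, also a limit. The position of compound 1 is therefore (the limit of > 100000 nM in this assay, at which 2 of the 3 values shown sit). Compound 2 `Cc1cccc(-c2nn3c(c2-c2ccncc2)C(C)C(C)(C)C3)c1C#N` gives a number, 97000 nM.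

Compound 4 `Cc1cccc(-c2nn3c(c2-c2ccncc2)C(C)C(C)(C)C3)n1` differs from compound 1 by hydrogen in place of methyl on an aromatic carbon, next to the ring nitrogen (hydrogen in place of methyl on an aromatic carbon), so that 2-methylpyridin-4-yl becomes pyridin-4-yl. For the measured compounds named here, no measured pair isolates this change. The expected size of the change is a number no higher from compound 1 to compound 4 (the limit leaves the size open), which means no expected shift in either direction beyond the scatter. That expectation rests on compound 2, which also carries pyridin-4-yl and gives 97000 nM. For compound 4 the estimated value is 100000 nM, with an expected range from 50000 nM to 200000 nM.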

Compound 4, half-maximal inhibitory concentration: > 100000 nM
Compound 4 was reported as a limit; the forecaster's own chance of this, stated with the estimate: 60%; the middle value sits exactly at the limit.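

In this assay compound 4 gives > 100000 nM, a limit of the assay and not a number. Compound 1 also sits at a limit, and no step can be read between the two. The compounds shown leave open what size, if any, the change from 2-methylpyridin-4-yl to pyridin-4-yl has.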